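The compounds below may be only part of what the source reports. "The series", "measured", "known", "first", "only" and "open" are said of these compounds alone.

Of the compounds shown here, three built on one shared core have been tested in a functional assay on the whole organism with Rattus norvegicus as the target; on this read-out lower numbers stand for an effect already at smaller amounts and higher numbers for an effect only at larger amounts of compound. Compound 1 `C=CCc1c(SC)nc2nc(C(=O)c3ccccc3)cn2c1C` gives 5 mg/kg. Compound 2 `COc1nc2nc(C(=O)c3ccccc3)cn2c(C)c1CC1CC1` gives 10 mg/kg, and compound 3 `CCCc1c(OC)nc2nc(C(=O)c3ccccc3)cn2c1CC` gives 10 mg/kg. Compound 2 stands level with compound 3 at the digits given, the two of them showing the highest numbers of the three, while compound 1 shows a lower number that still falls inside the usual scatter of this measurement. Compound 4 `CCCCc1c(OC)nc2nc(C(=O)c3ccccc3)cn2c1C` is the next compound, not yet measured. It differs from compound 2 in one place: propyl in place of cyclopropyl on a saturated chain carbon bound to an aromatic carbon. Within the data shown here, no measured pair shows this kind of change, so nothing among the three measured compounds speaks for a step beyond the scatter in either direction. Compound 4 is therefore expected to give about 10 mg/kg, with a range from 5 mg/kg to 20 mg/kg. This estimate amounts to a step of no change at the digits printed from compound 2 to compound 4 (within the scatter), which is expected to stay within the scatter.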

Compound 4, minimum effective dose: 2 mg/kg
For compound 4 the middle estimate is 5.0-fold (0.70 log units) above the measured one, outside the stated range (below it).
By their numbers in this assay, from the lowest: compound 4; then compounds 1, 2 and 3 (each within the scatter of the next).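

In this assay, replacing cyclopropyl with propyl gives a 5.0-fold lower number from compound 2 to compound 4 (0.70 log units; beyond the scatter), the first step in this series shown to lie beyond the scatter, so what is attached at this saturated chain carbon bound to an aromatic carbon matters to the read-out. Both groups hold the same carbon count and neither has donors or acceptors, so they differ here in the ring alone. No measurement available explains the step.

The compounds shown leave open whether a longer pentyl chain or a branched isobutyl group would lower or raise the number further. This single pair also cannot say whether the same change would act alike on other substitution of the shared core.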